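The source may report more compounds than this note shows. Statements on the series, on what has been measured and on what is new or still open speak of the compounds shown alone.

Compound 1 `COc1ccc(/C=C/C2CC(=O)C=CO2)cc1OC` and compound 2 `COc1cc(/C=C/C2CC(=O)C=CO2)cc(OC)c1OC` share one core; compound 3 `COc1ccc(/C=C/C2CC=CC(=O)O2)cc1` and compound 4 `COc1ccc(/C=C/C2CC=CC(=O)O2)c(OC)c1` share another, and the difference between the two cores is not broken down here. In a functional assay on U-251 cells (Homo sapiens) for inhibition, read by sulforhodamine B assay, with a stated time of 48 h (on this read-out lower numbers stand for stronger inhibition of growth and higher numbers for weaker inhibition of growth), compound 1 gives 86.9 uM, and compound 2 gives 102 uM; the step of a 1.2-fold higher number from compound 1 to compound 2 (0.07 log units; within the scatter) is the change (methoxy in place of hydrogen on an aromatic carbon). In this assay compound 3 gives 20.6 uM, the lowest of the three numbers and beyond the scatter from both compound 1 and compound 2. Compound 4 carries the same kind of change, (methoxy in place of hydrogen on an aromatic carbon), but here the entering methoxy is ortho to a group of 9 heavy atoms and meta to a methoxy group, whereas in compound 2 it is ortho to a methoxy group and meta to the group of 9 heavy atoms and to a methoxy group. Because the step of a 1.2-fold higher number from compound 1 to compound 2 (0.07 log units; within the scatter) stayed within the scatter, a step of similar size, a 1.2-fold higher number from compound 3 to compound 4 (0.08 log units; within the scatter), is expected in this assay. Compound 4 is therefore estimated at 25 uM, with a likely range of 10 uM to 60 uM.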

Compound 4, concentration for growth inhibition (reported as GI): 4.6 uM
Compound 4: middle estimate off by 5.4-fold (0.74 log units), on the high side, and the stated range ends above it.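

Methoxy in place of hydrogen on an aromatic carbon did not carry over unchanged between the two cores in this assay, where the new step is a 4.5-fold lower number from compound 3 to compound 4 (0.65 log units; beyond the scatter), and it differs from the earlier one: the same change on two cores in this assay, a 1.2-fold higher number (0.07 log units; within the scatter) from compound 1 to compound 2 and a 4.5-fold lower number (0.65 log units; beyond the scatter) from compound 3 to compound 4, 5.3-fold (0.72 log units) apart, beyond the scatter of two such steps. The entering methoxy also sits differently in compound 4, ortho to a group of 9 heavy atoms and meta to a methoxy group, so core and place change together across the two steps. With one pair on each core, the gap is not assigned to either, and no mechanism is shown.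

Still open, from the compounds shown here alone, is how the core of compound 1 responds to methoxy at the place it occupies in compound 4. Also open, going by these compounds, is whether hydroxyl, fluorine or a longer ethoxy chain there would follow compound 4.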